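Swapping one five-membered aromatic ring for another on compound 3

The compounds below may be only part of what the source reports. "The series", "measured", "known", "first", "only" and "open" are said of these compounds alone.

Of the compounds shown here, three with a shared nitro-catechol core have been tested in an assay on isolated protein for inhibition of Amine oxidase [flavin-containing] A (Homo sapiens), read by fluorescence; a higher number here means a weaker inhibitor, a lower number a stronger inhibitor. Compound 1 `N#Cc1cccc(/C=C/C(=O)c2cc(O)c(O)c([N+](=O)[O-])c2)c1` gives 58900 nM, compound 2 `O=C(/C=C/c1cccc(O)c1)c1cc(O)c(O)c([N+](=O)[O-])c1` gives 43900 nM, and compound 3 `CC(=O)N1N=C(c2cc(O)c(O)c([N+](=O)[O-])c2)CC1c1nccs1` gives 84600 nM, the highest of the three numbers, though within the scatter of both others. For the measured compounds named here, the only measured step, a 1.3-fold lower number from compound 1 to compound 2 (0.13 log units; within the scatter), concerns an aromatic substituent on a different scaffold and does not bear on the change at hand. Compound 4 `CC(=O)N1N=C(c2cc(O)c(O)c([N+](=O)[O-])c2)CC1c1ccoc1` differs from compound 3 by furan-3-yl in place of 1,3-thiazol-2-yl on a saturated ring carbon. Going by the values given here, no step informs this swap, so no shift beyond the scatter is expected; the estimated step is a 1.1-fold lower number from compound 3 to compound 4 (0.02 log units; within the scatter). Compound 4 is therefore expected to give about 80000 nM, ranging from 30000 nM to 200000 nM in this assay.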

Compound 4, half-maximal inhibitory concentration: 90900 nM
Compound 4: the middle estimate sits 1.1-fold (0.06 log units) below what was measured, within the range that was stated.
By their numbers in this assay, from the lowest: compounds 2, 1, 3 and 4 (each within the scatter of the next, the first and the last beyond it).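

In this assay, furan-3-yl in place of 1,3-thiazol-2-yl on this saturated ring carbon gives a 1.1-fold higher number from compound 3 to compound 4 (0.03 log units; within the scatter). At this position, then, going from a five-membered aromatic ring with 2 hetero atoms to one with 1 hetero atom does not move the number beyond the scatter. Nothing measured here offers an explanation for this result.

Going by these compounds, both groups tested are five-membered aromatic rings, so it stays open whether a phenyl ring, an amine or a carboxylic acid on this carbon would shift the number beyond the scatter.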